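The compounds below may be only part of what the source reports. "The series", "measured", "known", "first", "only" and "open" are said of these compounds alone.

Three compounds were measured in a toxicity assay on the whole organism (strain Icem-CET (SPF Caw)) for cytotoxicity, with Mus musculus as the target; a higher number here means that more compound is needed for the effect, a lower number that less compound is needed:

compound 1, `C#CCNC(=O)/C(C)=C(\C)c1ccc(Cl)cc1`, gives 200 mg/kg;
compound 2, `C/C(C(=O)NC1CC1)=C(\C)c1ccccc1`, gives 300 mg/kg;
compound 3, `C#CCNC(=O)/C(C)=C(\C)c1ccccc1`, gives 150 mg/kg.

Compound 3 and compound 1 differ in one place: chloro in place of hydrogen on an aromatic carbon. That change made a 1.3-fold higher number from compound 3 to compound 1 (0.12 log units; within the scatter). Compound 2 carries a different core from compound 3, and the difference between the two cores is not broken down here. The values of compound 2 and compound 3 lie within the scatter of each other, as do those of compound 2 and compound 1, so no order among the three can be stated.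

Compound 4, `C/C(C(=O)NC1CC1)=C(\C)c1ccc(Cl)cc1`, has not yet been measured in this assay. It differs from compound 2 by chloro in place of hydrogen on an aromatic carbon. The place of the change is described in the same words as for the pair compound 3 and compound 1, so it is the same change, appearing twice among these compounds. Because that change gave a 1.3-fold higher number from compound 3 to compound 1 (0.12 log units; within the scatter), compound 4 is expected to show a 1.3-fold higher number from compound 2 to compound 4 (0.12 log units; within the scatter). This expectation rests on a single earlier pair and a step that itself lay within the scatter, so it is loosely held. In this assay compound 4 is therefore estimated at 400 mg/kg, with a range from 200 mg/kg to 800 mg/kg.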

Compound 4, dose for half-maximal effect: 600 mg/kg
For compound 4 the middle estimate is 1.5-fold (0.18 log units) below the measured one; the range from low to high includes it.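

On the core of compound 2, chloro in place of hydrogen on an aromatic carbon gave a 2.0-fold higher number from compound 2 to compound 4 (0.30 log units; within the scatter) in this assay. Set beside the earlier step on the other core, the new step does not differ from it beyond what two such steps would be expected to scatter: the same change on two cores in this assay, a 1.3-fold higher number (0.12 log units; within the scatter) from compound 3 to compound 1 and a 2.0-fold higher number (0.30 log units; within the scatter) from compound 2 to compound 4, 1.5-fold (0.18 log units) apart, within the scatter of two such steps This shows that, within these two pairs, the change can be carried from one core to the other without any measurable disagreement, but it does not show that the chloro group has a real effect on the dose in this assay, as each step on its own lies within the scatter, and two pairs of compounds cannot establish that the same would hold on any further core.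

The compounds shown leave open whether another group in the same place, such as bromo, methoxy or a carboxylic acid, would give a step that stands clear of the scatter. They also leave open whether the chloro step would look the same with a longer chain or an amine on the amide side, or with chloro elsewhere on the six-membered aromatic ring.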